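Sulfonyl aryl exchange on the shared core

A few compounds are considered here, and "the series" means these few. Any claim that something is new, unique, unknown or untested is made for them only; others in the source may bear on it.

Compound 1 `CCn1cc(C(=O)O)c(=O)c2cc(F)c(N3CCN(C(=N)NS(=O)(=O)c4ccc(C)cc4)CC3)cc21` gives 43 nM in a functional assay on HL-60 cells (Homo sapiens) for antiproliferative activity, read by MTT assay, with a stated time of 72 h; on this read-out higher numbers stand for weaker inhibition and lower numbers for stronger inhibition. Compound 2 `N=C(NS(=O)(=O)c1ccccc1Cl)N1CCN(c2cc3c(cc2F)c(=O)c(C(=O)O)cn3C2CC2)CC1` gives 43 nM and compound 3 `Cc1ccc(S(=O)(=O)NC(=N)N2CCN(c3cc4c(cc3F)c(=O)c(C(=O)O)cn4C3CC3)CC2)cc1` gives 43 nM, so compound 1 sits level with both at the digits shown. The step from compound 1 to compound 4 `CCn1cc(C(=O)O)c(=O)c2cc(F)c(N3CCN(C(=N)NS(=O)(=O)c4cccc(Cl)c4)CC3)cc21` is 3-chlorophenyl in place of 4-methylphenyl on a sulfonyl sulfur. For the measured compounds named here, two measured steps bear on it: no change at the digits printed from compound 2 to compound 3 (within the scatter), which exchanges the aryl group on the sulfonyl sulfur, and no change at the digits printed from compound 1 to compound 3 (within the scatter), which alters the group on the aromatic nitrogen. Both sit within the scatter, and the aryl exchange is the closer match to the change at hand. Compound 4 is therefore expected to show no step beyond the scatter, no change at the digits printed from compound 1 to compound 4 (within the scatter). The estimate for compound 4 is 43 nM, with a range from 20 nM to 95 nM.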

Compound 4, half-maximal inhibitory concentration: 43 nM
Beside the measured number, compound 4's estimate shows no gap at the digits printed; measured number inside the range.
By their numbers in this assay, from the lowest: compounds 1, 2, 3 and 4 (each within the scatter of the next).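

In this assay the aryl exchange on the sulfonyl sulfur can now be read on the ethyl-bearing core as well: no change at the digits printed from compound 1 to compound 4 (within the scatter). The earlier aryl exchange, 4-methylphenyl in place of 2-chlorophenyl, stood on the cyclopropyl-bearing core, so both cores now show a step within the scatter, and 3-chlorophenyl joins the groups tolerated at this sulfonyl sulfur. No measurement available here accounts for this result. Still open, as far as these compounds go, is whether the read-out holds with a primary amine on the aryl ring, or with a longer alkyl chain replacing the aryl group on the sulfonyl sulfur.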